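Hydroxymethyl for carboxy on a pyrrolidine-bearing triazolyl hydroxamate

This account rests on a few compounds, and the source may have more. Where it says the series, first, only, none or still open, it means among the compounds named here.

Measured so far in an assay on Sf9 cells for inhibition of histone deacetylase 11 (Homo sapiens), read by fluorescence, tested at 0.5 uM; on this read-out lower numbers stand for less inhibition and higher numbers for more inhibition at the one concentration tested (going by the name of the read-out):
- compound 1 `O=C(NO)c1cccc(-c2cn([C@@H]3C[C@@H](CO)N(Cc4ccccc4)C3)nn2)c1`: < 10%
- compound 2 `O=C(NO)c1cccc(-c2cn([C@H]3C[C@@H](CO)N(Cc4ccccc4)C3)nn2)c1`: < 10%
- compound 3 `O=C(NO)c1cccc(-c2cn([C@H]3C[C@H](C(=O)O)N(Cc4ccccc4)C3)nn2)c1`: < 10%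

Each of these three values is a limit of this assay, not a number. Compound 3 therefore stands at the limit of < 10%, with no number of its own; the other two values shown sit at the same limit (the limit of < 10% in this assay, at which 3 of the 3 values shown sit). Within the data shown here, the only measured step between compounds differing in one place is a step that the two limits leave unreadable from compound 1 to compound 2, which rests on the fact that the fact that compounds 1 and 2 differ only in the configuration as drawn and gives no readable size.

Compound 4 `O=C(NO)c1cccc(-c2cn([C@H]3C[C@H](CO)N(Cc4ccccc4)C3)nn2)c1` is not yet measured. It differs from compound 3 as follows: hydroxymethyl in place of carboxy on a saturated ring carbon. No measured step covers this change, so nothing among the shown compounds points to a gain in inhibition. Since every value shown sits at the limit (the limit of < 10% in this assay, at which 3 of the 3 values shown sit), compound 4 is expected to show no step beyond the scatter, with a step that the limit leaves unreadable from compound 3 to compound 4. The estimate for compound 4 in this assay is 5%, ranging from 0% to 15%.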

Compound 4, a percentage reported as inhibition, at one concentration (the size of the read-out at that concentration, not a potency): < 10%
Compound 4 was reported as a limit; the forecaster's own chance of this, stated with the estimate: 80%; the middle value does not contradict the limit.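

In this assay compound 4 gives < 10%, which is a limit of the assay and not a number. The steps to it from compound 1, compound 2 and compound 3 cannot be read. The compounds shown leave open whether swapping carboxy for hydroxymethyl, or changing the configuration, alters inhibition at all.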